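Cytotoxicity notes: methyl on the imidazole of compound 1

This account rests on a few compounds, and the source may have more. Where it says the series, first, only, none or still open, it means among the compounds named here.

Measured so far in an ADME assay on HepG2 2.2.15 cells (Homo sapiens) for cytotoxicity, with a stated time of 9 days; a higher number here means that more compound is tolerated, a lower number that less compound is tolerated:
compound 1 `Cc1ccc(SCc2nc3c(Cn4ccnc4)c(O)ccc3n2C)cc1`, which gives 60800 nM;
compound 2 `Cn1c(CS(=O)(=O)c2ccccc2)nc2c(Cn3ccnc3)c(O)ccc21`, which gives 623000 nM.

Going by the values given here, compound 1 holds the lowest of the two numbers; the only other point is compound 2, reached by a 10-fold higher number from compound 1 to compound 2 (1.01 log units; beyond the scatter), a change on the saturated chain carbon bound to an aromatic carbon. Compound 3 `Cc1ccc(SCc2nc3c(Cn4ccnc4C)c(O)ccc3n2C)cc1` differs from compound 1 elsewhere: methyl in place of hydrogen on an aromatic carbon. Among the compounds with values here, no measured step touches this imidazole position, so nothing recorded bears on it, and in this assay the expected step of a 1.0-fold lower number from compound 1 to compound 3 (0.01 log units; within the scatter) is none beyond the scatter. Compound 3 is estimated at 60000 nM, range 25000 nM to 150000 nM.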

Compound 3, half-maximal cytotoxic concentration: 91200 nM
Estimate against measurement, compound 3: 1.5-fold (0.18 log units) below; the range from low to high includes it.
By their numbers in this assay, from the lowest: compounds 1 and 3 (each within the scatter of the next); then compound 2.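

In this assay, the imidazole position now has its first reading: swapping 1H-imidazol-1-yl for 2-methyl-1H-imidazol-1-yl gives no change beyond the scatter (a 1.5-fold higher number from compound 1 to compound 3 (0.18 log units; within the scatter)). A methyl between two ring nitrogen atoms is thus tolerated on the (4-methylphenyl)sulfanyl compound, whereas the chain change gave a clear shift (a 10-fold higher number from compound 1 to compound 2 (1.01 log units; beyond the scatter)). Nothing available explains either result.

Open, going by these compounds, is whether an ethyl group, a longer chain or an amine at this carbon would stay as flat. Also open, on these data alone, is whether the methyl behaves alike on the phenylsulfonyl compound 2.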